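A few compounds are considered here, and "the series" means these few. Any claim that something is new, unique, unknown or untested is made for them only; others in the source may bear on it.

Compound 1 `COC(=O)CNC(=O)CCC/C=C\NC(=O)c1ccc(Cc2ccc(Br)cc2)cc1` and compound 2 `CCCCCCOc1ccc(C(=O)N/C=C\CCCC(=O)NCC(=O)OC)cc1` share one core. In a physicochemical assay (on this read-out higher numbers stand for a longer-lived compound and lower numbers for a shorter-lived compound), compound 1 gives 12 h and compound 2 gives 5 h. Going by the values given here, the single measured step, a 2.4-fold lower number from compound 1 to compound 2 (0.38 log units; beyond the scatter), places compound 2 lowest of the two numbers, with compound 1 the nearest at a higher value. Compound 3 `CCOc1ccc(Cc2ccc(C(=O)N/C=C\CCCC(=O)NCC(=O)OC)cc2)cc1` is not yet measured; it differs from compound 2 by 4-ethoxybenzyl in place of hexyloxy on an aromatic carbon. Among the compounds with values here, the step from compound 1 to compound 2 bears on this change, as it exchanged a benzyl group for hexyloxy at the same place and lowered the number; compound 3 restores a benzyl group, though 4-ethoxybenzyl rather than 4-bromobenzyl, and no measured pair compares ethoxy with bromo. A modest rise is therefore expected, a 1.8-fold higher number from compound 2 to compound 3 (0.26 log units; within the scatter), of uncertain size. For compound 3 the estimate in this assay is 9 h, expected to fall between 4 h and 18 h.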

Compound 3, half-life: 20 h
Estimate against measurement, compound 3: 2.2-fold (0.35 log units) below; measured number outside the range, above it.
By their numbers in this assay, from the lowest: compound 2; then compounds 1 and 3 (each within the scatter of the next).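

In this assay, the change from hexyloxy to 4-ethoxybenzyl on this aromatic carbon gives a 4.0-fold higher number from compound 2 to compound 3 (0.60 log units; beyond the scatter) and so reverses the earlier fall, with a step beyond the scatter. Ethoxy in place of bromo gives a 1.7-fold higher number from compound 1 to compound 3 (0.22 log units; within the scatter) and stays within the scatter, so the two substituents on the benzyl group cannot be told apart on this read-out, and compound 2, the only compound here without a benzyl group, stands apart from both. Nothing measured here accounts for either step.

The compounds shown do not separate the entering aromatic ring from the overall size of the group, since hexyloxy is the only open chain among them. On these data alone, an unsubstituted benzyl group, a shorter chain such as methoxy, or an amine or carboxylic acid on the benzyl group remain open.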